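The source may report more compounds than this note shows. Statements on the series, on what has been measured and on what is new or still open speak of the compounds shown alone.

Measured so far:
compound 1 `COc1ccc(N2C(=O)C(C)(C)c3cccnc32)cc1`: 0%
compound 2 `CC1(C)C(=O)N(c2cccc(Cl)c2)c2ncccc21`: 0%

In a functional assay on the whole organism with Rattus norvegicus as the target, at a dose of 25 mg/kg (a higher number here means more inhibition at the dose given (going by the name of the read-out), a lower number less inhibition), compound 1 gives 0%. Compound 2 gives 0%, level with compound 1 at the digits printed, so no order between the two is read. Compound 3 `CC1(C)C(=O)N(c2ccc(F)cc2)c2ncccc21` is not yet measured. It differs from compound 1 by fluoro in place of methoxy on an aromatic carbon. Among the measured compounds shown here, no measured pair speaks to this change, so the step expected is a number 2 percentage points higher from compound 1 to compound 3 (within the scatter), none beyond the scatter, because compound 1 gives 0%. Compound 3 is thus expected to give 2%, with a range from 0% to 15%.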

Compound 3, a percentage reported as inhibition, in the whole organism at one dose (the size of the read-out at that dose, not a potency): 0%
The estimate for compound 3 lay 2 percentage points above the measured number; the range from low to high includes it.
By their numbers in this assay, from the lowest: compounds 1, 2 and 3 (each within the scatter of the next).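

In this assay, among the compounds shown here, fluoro in place of methoxy on an aromatic carbon, para to a large group, gives no change at the digits printed from compound 1 to compound 3 (within the scatter) and is the first step that can be read. At this place the change does not separate the two compounds at the dose given, so neither group stands out here. On these data alone, whether another group at this place, such as an amine, a carboxylic acid or a longer chain, would give a different read-out stays open. No measured evidence bears on this result.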